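The source may hold more compounds than are shown below. What is called first, only, known or untested is meant among the compounds shown, and "the series" means these compounds.

Measured so far:

Compound 1, `CC(C)N(C(=O)CN1C=CN(c2ccccc2)C(=O)[C@H](Cc2n[nH]c3ccccc23)C1=O)c1ccccc1` — 1070 nM
Compound 2, `COc1ccc(N(C(=O)CN2C=CN(c3ccccc3)C(=O)[C@H](Cc3n[nH]c4ccccc34)C2=O)C(C)C)cc1` — 339 nM
Compound 3, `COc1ccc(N(C(=O)CN2C=CN(c3ccccc3)C(=O)C(Cc3n[nH]c4cc(F)ccc34)C2=O)C(C)C)cc1` — 355 nM

The three measured compounds were tested in a functional assay on CHO cells for agonist activity at Melanocortin receptor 4 (Homo sapiens), read by a luciferase reporter, with a stated time of 4 h; a higher number here means that more compound is needed for the effect, a lower number that less compound is needed. Compound 1 and compound 2 share a core and differ in one place: hydrogen in place of methoxy on an aromatic carbon. That single change gave a 3.2-fold higher number from compound 2 to compound 1 (0.50 log units; beyond the scatter), so the methoxy-bearing compound 2 needed less compound for the effect than compound 1.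

Compound 3 carries a different core from compound 2; the difference between the two cores is not broken down here. In this assay compound 3 gives 355 nM, a number that sits within the scatter of compound 2 and is clearly different from compound 1.

Compound 4, `CC(C)N(C(=O)CN1C=CN(c2ccccc2)C(=O)C(Cc2n[nH]c3cc(F)ccc23)C1=O)c1ccccc1`, has not yet been measured. It differs from compound 3 in one place: hydrogen in place of methoxy on an aromatic carbon. The place of the change is described in the same words as for the change from compound 2 to compound 1, so this is the same change, made on the core of compound 3 instead of the core of compound 2.

The expectation for compound 4 therefore rests on the pair compound 2 and compound 1: the step of a 3.2-fold higher number from compound 2 to compound 1 (0.50 log units; beyond the scatter) is taken as the best guide, and a step of similar size is expected, a 3.1-fold higher number from compound 3 to compound 4 (0.49 log units; beyond the scatter). On that basis compound 4 is estimated at 1100 nM, with a likely range from 500 nM to 2500 nM. Whether the change made on this second core gives the same result is the question the measurement will answer.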

Compound 4, half-maximal effective concentration: 537 nM
Compound 4: the middle estimate sits 2.0-fold (0.31 log units) above what was measured; low and high end bracket the measured number.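

On one core, replacing methoxy with hydrogen gives a 1.5-fold higher number from compound 3 to compound 4 (0.18 log units; within the scatter), whereas on the other core the same replacement gave a 3.2-fold higher number from compound 2 to compound 1 (0.50 log units; beyond the scatter). Only the second of these steps can be told apart from ordinary variation between repeat measurements, yet the two steps themselves cannot be told apart: the same change on two cores in this assay, a 3.2-fold higher number (0.50 log units; beyond the scatter) from compound 2 to compound 1 and a 1.5-fold higher number (0.18 log units; within the scatter) from compound 3 to compound 4, 2.1-fold (0.32 log units) apart, within the scatter of two such steps. The result is therefore compatible with the change carrying over from one core to the other at a similar size, but it does not prove this, and two pairs cannot fix a typical size for the step or show that it would hold on any further core.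

The compounds shown carry only methoxy or hydrogen at this place on the ring, which leaves open what an ethoxy group, a chlorine atom or an amine there would give in this assay. They also leave open whether a longer chain, such as butyl, in place of the isopropyl group would alter the number or the size of the step seen on removing methoxy.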